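A few compounds are considered here, and "the series" means these few. Any claim that something is new, unique, unknown or untested is made for them only; others in the source may bear on it.

Measured compounds in a functional assay for inhibition of nuclear factor NF-kappa-B complex (Homo sapiens); on this read-out higher numbers stand for weaker inhibition and lower numbers for stronger inhibition:
compound 1 `COc1ccc2c(c1)OC(c1cc(OC)c(OC)c(OC)c1)C(C(=O)OCCc1ccccc1)=C2`, value 16200 nM
compound 2 `CCCC(=O)C1=Cc2ccc(OC)cc2OC1c1cc(OC)c(OC)c(OC)c1`, value 11700 nM
compound 3 `CCCCNC(=O)C1=Cc2ccc(OC)cc2OC1c1cc(OC)c(OC)c(OC)c1`, value 25500 nM

Of the three numbers, compound 3 gives the highest in this assay. Its nearest neighbour is compound 1, with a 1.6-fold higher number from compound 1 to compound 3 (0.20 log units; within the scatter). The gap to compound 2 is larger, a 2.2-fold higher number from compound 2 to compound 3 (0.34 log units; beyond the scatter), a modest step. Between compound 1 and compound 2 the change amounts to a 1.4-fold lower number from compound 1 to compound 2 (0.14 log units; within the scatter).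

Compound 4 `CCNC(=O)C1=Cc2ccc(OC)cc2OC1c1cc(OC)c(OC)c(OC)c1` has not yet been measured in this assay. It differs from compound 3 by hydrogen in place of ethyl on a saturated chain carbon, two bonds along the chain from an amide-type nitrogen: the butylamino group on the carbonyl carbon becomes ethylamino.

Among the compounds with values here, none of the measured steps is of this kind. Within the data shown here, the three steps all swap the whole substituent on the carbonyl carbon, phenethyloxy, propyl or butylamino; no measured pair shortens a chain while keeping the amide-type nitrogen. Among the measured compounds shown here, the only bearing they have is general: the three substituents, different as they are, span a narrow band in this assay, with only the step from compound 2 to compound 3 reaching beyond the scatter. A change confined to two chain carbons is therefore expected to move the number less than that, in no firm direction.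

Compound 4 is thus expected at 28000 nM in this assay, within 12000 nM to 65000 nM, which is an expected step of a 1.1-fold higher number from compound 3 to compound 4 (0.04 log units; within the scatter), within the scatter.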

Compound 4, half-maximal inhibitory concentration: > 50000 nM
Compound 4 gave a limit, no number (the forecaster's own chance of this, stated with the estimate: 15%); at least 1.7-fold (0.25 log units) between middle value and limit.
By their numbers in this assay, from the lowest: compounds 2, 1 and 3 (each within the scatter of the next, the first and the last beyond it). At a limit, above all of these: compound 4.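

In this assay compound 4 gives a limit and not a number: the limit of > 50000 nM in this assay, at which 1 of the 4 values shown sits. Shortening butylamino to ethylamino is the only change shown that keeps the amide-type nitrogen and alters just the chain, and it gives an at least 1.9-fold higher number from compound 3 to compound 4 (0.29 log units; that floor lies within the scatter), so the chain change is not established as beyond the scatter, although the true gap may be wider than this floor. Set against the other substituents on the carbonyl carbon, the floor does clear the scatter, with an at least 4.2-fold higher number from compound 2 to compound 4 (0.63 log units; beyond the scatter) and an at least 3.0-fold higher number from compound 1 to compound 4 (0.48 log units; beyond the scatter), so ethylamino stands apart from both propyl and phenethyloxy, whereas butylamino stands apart only from propyl, with a 1.6-fold higher number from compound 1 to compound 3 (0.20 log units; within the scatter) and a 2.2-fold higher number from compound 2 to compound 3 (0.34 log units; beyond the scatter).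

Going by these compounds, with two amide chains and one of them known only as a limit, the size of the chain-length effect remains open, and no trend in chain length can be drawn from this pair. Also open, on these data alone, is how a longer chain such as hexylamino would read in this assay, and whether a carboxylic acid in place of the amide would read any differently on the shared core.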